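Swapping the Aryl Group on a Triazole Ester

The source may report more compounds than this note shows. Statements on the series, on what has been measured and on what is new or still open speak of the compounds shown alone.

Compound 3, `COc1cc(OC)cc(-c2cn(-c3ccc(O)c(C(=O)OCCCc4ccccc4)c3)nn2)c1`, was tested in a functional assay on HCT-116 cells (Homo sapiens) for inhibition, read by MTT assay, with a stated time of 2 days, tested at 10 uM (on this read-out higher numbers stand for more inhibition at the one concentration tested (going by the name of the read-out) and lower numbers for less inhibition), where compound 3 gives 19%. Among the three compounds measured so far, compound 3 stands second highest. Compound 1, `O=C(OCCCc1ccccc1)c1cc(-n2cc(-c3cccc(O)c3)nn2)ccc1O`, gives 11% in this assay, and the gap between compound 1 and compound 3 lies within the usual scatter. Within the data shown here, compound 2, `COc1ccccc1-c1cn(-c2ccc(O)c(C(=O)Nc3cccc(C(F)(F)F)c3)c2)nn1`, gives 61%, a number beyond the scatter above compound 3; compound 2 differs from compound 3 in more than one place, so no single step connects the two.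

Compound 4, `COc1ccccc1-c1cn(-c2ccc(O)c(C(=O)OCCCc3ccccc3)c2)nn1`, has not yet been measured. It differs from compound 3 in one place: 2-methoxyphenyl in place of 3,5-dimethoxyphenyl on an aromatic carbon. Among the measured compounds shown here, the only measured step that bears on this change is a number 8 percentage points higher from compound 1 to compound 3 (within the scatter), which also exchanged one aromatic group for another on an aromatic carbon of the shared core and left the read-out within the scatter. Compound 2 carries the same 2-methoxyphenyl group as compound 4, but its higher number cannot be tied to that group alone. A small step with no clear direction is therefore expected here, a number 1 percentage points higher from compound 3 to compound 4 (within the scatter). Compound 4 is estimated to give 20% in this assay, with a likely range from 5% to 40%.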

Compound 4, a percentage reported as inhibition, at one concentration (the size of the read-out at that concentration, not a potency): 7%
Beside the measured number, compound 4's estimate is 13 percentage points above it; measured number inside the range.
By their numbers in this assay, from the lowest: compounds 4, 1 and 3 (each within the scatter of the next, the first and the last beyond it); then compound 2.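

On the aromatic carbon of the five-membered ring, the aryl group can shift the read-out in this assay: 2-methoxyphenyl in place of 3,5-dimethoxyphenyl gives a number 12 percentage points lower from compound 3 to compound 4 (beyond the scatter) as the first step at this place to lie beyond the scatter, while a number 4 percentage points lower from compound 1 to compound 4 (within the scatter) stays within it, so only compound 3 and compound 4 are told apart among these three aryl groups on the ester. A far larger step appears at the carbonyl carbon with the 2-methoxyphenyl group held fixed, where 3-phenylpropoxy in place of (3-(trifluoromethyl)phenyl)amino gives a number 54 percentage points lower from compound 2 to compound 4 (beyond the scatter) as the biggest change seen in this small series. Nothing available explains either the modest step or the large one.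

Among these compounds, the aryl step is seen only on the 3-phenylpropoxy ester, so it remains open whether 3,5-dimethoxyphenyl and 2-methoxyphenyl would differ in the same way on the amide of compound 2. Also open, from the compounds shown here alone, is how a carboxylic acid or a simple amine would read out in place of 3-phenylpropoxy on the carbonyl carbon.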